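Halogen exchange at one aromatic carbon: chloro to bromo

The compounds below may be only part of what the source reports. "The series", "measured", "known", "first", "only" and "open" are said of these compounds alone.

Measured so far:
compound 1 `O=C(Nc1cc(-c2ccccc2)nn1-c1ccccc1)c1ccccc1`: 203 nM
compound 2 `O=C(Nc1cc(-c2ccccc2)nn1-c1ccccc1Cl)c1ccccc1`: 62 nM

In a functional assay on cells for positive allosteric modulation of metabotropic glutamate receptor 5 (Rattus norvegicus), read by calcium flux (a lower number here means that less compound is needed, a higher number that more compound is needed for the effect), compound 1 gives 203 nM and compound 2 gives 62 nM. Going by the values given here, compound 2 stands at the lowest of the two numbers; the only step into it, a 3.3-fold lower number from compound 1 to compound 2 (0.52 log units; beyond the scatter), is modest and beyond the scatter. Compound 3 `O=C(Nc1cc(-c2ccccc2)nn1-c1ccccc1Br)c1ccccc1` is not yet measured. The change from compound 2 to compound 3 is bromo in place of chloro on an aromatic carbon, read one bond further out as 2-chlorophenyl to 2-bromophenyl. Among the compounds with values here, no measured step shows this exchange directly; the single known step, a 3.3-fold lower number from compound 1 to compound 2 (0.52 log units; beyond the scatter), concerns hydrogen to chloro at that carbon and bears on it only loosely, in that a halogen there already helped. Bromo in place of chloro is expected to leave this assay little changed, any shift sitting near the edge of the scatter. For compound 3 the estimate in this assay is 50 nM, range 20 nM to 150 nM, an expected step of a 1.2-fold lower number from compound 2 to compound 3 (0.09 log units; within the scatter).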

Compound 3, half-maximal effective concentration: 200 nM
Beside the measured number, compound 3's estimate is 4.0-fold (0.60 log units) below it; measured number outside the range, above it.
By their numbers in this assay, from the lowest: compound 2; then compounds 3 and 1 (each within the scatter of the next).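

At this aromatic carbon, ortho to a large group, the identity of the halogen matters in this assay: bromo in place of chloro gives a 3.2-fold higher number from compound 2 to compound 3 (0.51 log units; beyond the scatter) and so the gain seen with chloro does not extend to bromo. Bromo in place of hydrogen gives a 1.0-fold lower number from compound 1 to compound 3 (0.01 log units; within the scatter) and leaves those two compounds indistinguishable in this assay, so that among the three compounds only compound 2 stands apart. Nothing available explains why chloro and bromo part here.

Open, on these data alone, is how fluoro, methyl or methoxy at this same carbon would read in this assay, and thus whether chloro is a narrow optimum or one member of a wider set of tolerated groups. Also open, as far as these compounds go, is whether the chloro-to-bromo difference persists when an amine or a carboxylic acid is carried elsewhere on the shared core.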